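Moving one methoxy group on a weak growth inhibitor

A few compounds are considered here, and "the series" means these few. Any claim that something is new, unique, unknown or untested is made for them only; others in the source may bear on it.

Measured in a functional assay on HepG2 cells (Homo sapiens) for inhibition, read by MTT assay; a lower number here means a stronger inhibitor of growth, a higher number a weaker inhibitor of growth:
- compound 1 (`COc1cccc(C(=O)Nc2cccc(-c3cc(=O)c4c(OC)c(OC)c(OC)cc4o3)c2)c1`) gives 7060 nM
- compound 2 (`COc1ccc(C(=O)Nc2cccc(-c3cc(=O)c4c(O)c(OC)c(OC)cc4o3)c2)cc1`) gives > 100000 nM

The reading for compound 2 is > 100000 nM in this assay, which is a limit of the assay and not a number.

Compound 3 (`COc1cccc(C(=O)Nc2cccc(-c3cc(=O)c4c(O)c(OC)c(OC)cc4o3)c2)c1`) has the same atoms as compound 2, joined differently, with 3-methoxyphenyl in place of 4-methoxyphenyl on a carbonyl carbon.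

Going by the values given here, no measured pair of compounds shows what a change like this does, so the expectation rests on thin ground. Among the compounds with values here, the only number comes from compound 1, which gives 7060 nM and carries the same 3-methoxyphenyl group as compound 3. That gives a slight reason to expect some growth inhibition to appear, though compound 3 may also return only a limit. The expected change is a modest move towards stronger inhibition, estimated as an at least 1.4-fold lower number from compound 2 to compound 3 (0.15 log units; that floor lies within the scatter) in this assay overall. In this assay compound 3 is estimated at 70000 nM with an expected range that has 20000 nM as its lower end and 150000 nM as its upper end.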

Compound 3, concentration for 50% growth inhibition: > 100000 nM
Compound 3 ended at the assay's limit; the forecaster's own chance of this, stated with the estimate: 50%; middle value at least 1.4-fold (0.15 log units) from the limit.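

In this assay, moving the methoxy group from 4-methoxyphenyl to 3-methoxyphenyl on the carbonyl carbon brings no readable growth inhibition, and the step between these two compounds cannot be read, since both values are limits and not numbers: the limit of > 100000 nM in this assay, at which 2 of the 3 values shown sit.

Going by these compounds alone, the one readable step is a different change, hydrogen in place of methyl on an oxygen on an aromatic ring, which gives an at least 14-fold higher number from compound 1 to compound 3 (1.15 log units; beyond the scatter). With the 3-methoxyphenyl group held the same, that single methyl separates a measurable value from the limit in this pair, something compound 1 and compound 2 could not show, as they differ in two places.

From the compounds shown here alone, whether 4-methoxyphenyl and 3-methoxyphenyl differ at all stays open, and a pair carrying the methyl on that oxygen would be needed to put numbers on both groups. The compounds shown also do not tell what an amine or a carboxylic acid in place of the methoxy group would do to growth inhibition.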